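Prostanoid series: ring and chain change at the omega hydroxyl

A few compounds are considered here, and "the series" means these few. Any claim that something is new, unique, unknown or untested is made for them only; others in the source may bear on it.

Measured so far:
compound 1 `COC(=O)CC/C=C\CC[C@H]1C(=O)C[C@@H](O)[C@@H]1/C=C/CC(C)(O)CCC1CCCC1` — 0.00009 mg/kg
compound 2 `COC(=O)CC/C=C\CC[C@H]1C(=O)C[C@@H](O)[C@@H]1/C=C/CC(C)(O)CCC1CC1` — 0.00009 mg/kg
compound 3 `COC(=O)CC/C=C\CC[C@H]1C(=O)C[C@@H](O)[C@@H]1/C=C/C[C@@](C)(O)/C=C/C1=CCCCC1` — 0.0003 mg/kg

In a functional assay on the whole organism (stomach) with Canis familiaris (Canis lupus familiaris) as the target (a higher number here means that more compound is needed for the effect, a lower number that less compound is needed), compound 1 gives 0.00009 mg/kg. On the numbers shown compound 1 stands level with compound 2 at the digits printed, the two together at the low end of the three; compound 3 sits furthest from it, at a number beyond the scatter.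

Compound 4 `COC(=O)CC/C=C\CC[C@H]1C(=O)C[C@@H](O)[C@@H]1/C=C/C[C@@](C)(O)/C=C/C1CCC1` is not yet measured. It differs from compound 1 as follows: 3-cyclobutyl-1-hydroxy-1-methylprop-2-en-1-yl in place of 3-cyclopentyl-1-hydroxy-1-methylpropyl on a saturated chain carbon bound to a double-bonded chain carbon

Within the data shown here, only one measured step bears on the ring part of this change: no change at the digits printed from compound 1 to compound 2 (within the scatter). A ring of different size on the saturated chain carbon therefore gave nothing beyond the scatter. Among the measured compounds shown here, the double bond in the entering group has no step of its own; compound 3, which also carries a double bond there, gives 0.0003 mg/kg against compound 1 at 0.00009 mg/kg. For compound 4 a small rise is expected, a 2.2-fold higher number from compound 1 to compound 4 (0.35 log units; beyond the scatter), leaning toward compound 3 because of 0.0003 mg/kg while the ring change alone is expected to add nothing. Compound 4 is thus estimated at 0.0002 mg/kg, with a range from 0.00007 mg/kg to 0.0006 mg/kg.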

Compound 4, dose for half-maximal effect: 0.00005 mg/kg
For compound 4 the middle estimate is 4.0-fold (0.60 log units) above the measured one, outside the stated range (below it).
By their numbers in this assay, from the lowest: compounds 4, 1 and 2 (each within the scatter of the next); then compound 3.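

In this assay the entering 3-cyclobutyl-1-hydroxy-1-methylprop-2-en-1-yl group gives a 1.8-fold lower number from compound 1 to compound 4 (0.26 log units; within the scatter) and a 1.8-fold lower number from compound 2 to compound 4 (0.26 log units; within the scatter) and so stays within the scatter of both saturated compounds, which shows that a double bond in this chain can be carried without a rise in the number when the chain ends in cyclobutyl. With the double bond kept in both compounds, the change of the end ring alone gives a 6.0-fold lower number from compound 3 to compound 4 (0.78 log units; beyond the scatter) and stands beyond the scatter, so the higher number of compound 3 goes with its cyclohex-1-en-1-yl group and not with the double bond as such. Nothing measured on these compounds offers an explanation for either result.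

The contributions of the double bond, the cyclobutyl ring and the defined stereocentre that enter together in compound 4 remain unseparated, as does the effect of the opposite configuration at that stereocentre. Also open, as far as these compounds go, is how this assay would respond to a phenyl ring or an amine at the chain end, a longer chain before the ring, or a carboxylic acid in place of the methyl ester.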